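Hydroxy in place of nitro on the biaryl ether series

A few compounds are considered here, and "the series" means these few. Any claim that something is new, unique, unknown or untested is made for them only; others in the source may bear on it.

Working notes. Compound 1 `Cc1ccc(-c2ccccc2OC(C)C2=NCCN2)cc1` in a functional assay on CHO cells for agonist activity at Alpha-2B adrenergic receptor (Homo sapiens) (on this read-out lower numbers stand for smaller maximal responses and higher numbers for larger maximal responses), gives only a limit of the assay, < 0.3. Compound 2 `CC(Oc1ccccc1-c1cccnc1)C1=NCCN1` in this assay gives 0.5. Within the data shown here, the single measured step, a number at least 0.20 higher from compound 1 to compound 2 (beyond the scatter), is the only change so far that moves this read-out beyond the scatter, and it concerns the aromatic ring rather than a substituent on it. Compound 3 `CC(Oc1ccccc1-c1ccccc1[N+](=O)[O-])C1=NCCN1` in this assay likewise returns a limit of the assay, < 0.3. Compound 3 therefore stands at the limit of < 0.3 in this assay, at which 2 of the 3 values shown sit, so its true maximal response is not known, only bounded.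

Compound 4 `CC(Oc1ccccc1-c1ccccc1O)C1=NCCN1` differs from compound 3 by hydroxy in place of nitro on an aromatic carbon. Among the measured compounds shown here, no measured step covers a hydroxy for nitro exchange, and the step from compound 1 to compound 2 does not bear on it; no direction can be read from the data. A change of modest size at most is expected, with the outcome as likely to stay at the limit as to rise above it.

Compound 4 is estimated at 0.3, within a range of 0.1 to 0.5. For compound 4 the expected step is a number no lower from compound 3 to compound 4 (the limit leaves the size open).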

Compound 4, intrinsic activity: the largest response reached, as a fraction of the reference agonist's: < 0.3
Compound 4: a limit, no number (the forecaster's own chance of this, stated with the estimate: 50%); the middle value lies on the limit itself.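

Replacing pyridin-3-yl with 2-hydroxyphenyl on this aromatic carbon gives, in this assay, a number at least 0.20 lower from compound 2 to compound 4 (beyond the scatter), so a hydroxy-bearing phenyl ring does not keep the response seen with the pyridine ring. Compound 4 gives only a limit of the assay, < 0.3, so the steps to it from compound 1 and compound 3 cannot be read. Compound 2 is now the only compound shown that returns a number, and most of the set sits at one limit: the limit of < 0.3 in this assay, at which 3 of the 4 values shown sit.

On these data alone, how compound 1, compound 3 and compound 4 rank among themselves stays open, as all three are limits. As far as these compounds go, whether a number can be reached only with the pyridin-3-yl ring also stays open: a pyridin-4-yl ring or a phenyl ring carrying an amine or a carboxylic acid would bear on this.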